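Ethyl to methyl on compound 2

This account rests on a few compounds, and the source may have more. Where it says the series, first, only, none or still open, it means among the compounds named here.

In a functional assay on the whole organism with Mus musculus as the target (a higher number here means that more compound is needed for the effect, a lower number that less compound is needed), compound 2 `CCN(C)C(=O)/C=C1\CCc2c(F)cc(F)cc21` gives 56 mg/kg and compound 3 `CNC(=O)/C=C1\CCc2cc(F)c(F)cc21` gives 96 mg/kg and these two values lie within the scatter of each other. Compound 1 `CN(C)C(=O)/C=C1\CCc2ccc(F)cc21` reads > 100 mg/kg and this is a limit of the assay, not a number. Compound 4 `CN(C)C(=O)/C=C1\CCc2c(F)cc(F)cc21` follows from compound 2 through hydrogen in place of methyl on a saturated chain carbon bound to an amide-type nitrogen with hydrogen in place of methyl on a saturated chain carbon bound to an amide-type nitrogen, that is, ethyl to methyl. Within the data shown here, no measured step isolates this change, so no shift beyond the scatter is expected in this assay here. The estimated 1.2-fold higher number from compound 2 to compound 4 (0.06 log units; within the scatter) is small and its direction is uncertain. For compound 4 the estimated value is 65 mg/kg with an expected range from 32 mg/kg to 130 mg/kg at this stage.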

Compound 4, dose for half-maximal effect: 50 mg/kg
Estimate against measurement, compound 4: 1.3-fold (0.11 log units) above, and the stated range covers the measured number.
By their numbers in this assay, from the lowest: compounds 4, 2 and 3 (each within the scatter of the next). At a limit, above all of these: compound 1.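

The ethyl on the amide nitrogen can give way to methyl with no shift beyond the scatter in this assay (a 1.1-fold lower number from compound 2 to compound 4 (0.05 log units; within the scatter)), so this position tolerates that shortening in the pair shown. Fluoro in place of hydrogen on an aromatic carbon gives the first step to a compound held at a limit (an at least 2.0-fold lower number from compound 1 to compound 4 (0.30 log units; that floor lies within the scatter)). Compound 1 stands at a limit of the assay, so only a floor can be read for that step: the limit of > 100 mg/kg in this assay, at which 1 of the 4 values shown sits.

As far as these compounds go, whether a longer chain such as propyl, or a cyclic amine such as pyrrolidine, moves the number beyond the scatter stays open. From the compounds shown here alone, a carboxylic acid in place of the amide also stays open.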